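This account rests on a few compounds, and the source may have more. Where it says the series, first, only, none or still open, it means among the compounds named here.

Measured so far, in a functional assay on SGC-7901 cells (Homo sapiens) for antiproliferative activity, read by MTT assay, with a stated time of 72 h; on this read-out higher numbers stand for weaker inhibition and lower numbers for stronger inhibition:
- compound 1 `COc1cc(-n2cnc3ccc(-c4ccccc4Cl)cc32)cc(OC)c1OC`: > 10000 nM
- compound 2 `COc1cc(-n2cnc3ccc(-c4ccccc4)cc32)cc(OC)c1OC`: 290 nM
- compound 3 `COc1cc(-c2ccc3ncn(-c4cc(OC)c(OC)c(OC)c4)c3c2)cc(OC)c1OC`: > 10000 nM

Compound 1 gives only a limit of this assay, > 10000 nM. Compound 3 likewise gives only a limit, > 10000 nM. Going by the values given here, compound 2 gives 290 nM, and this is the only real number among the three; the other two sit at the limit of > 10000 nM in this assay, at which 2 of the 3 values shown sit.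

Among the compounds with values here, the one step that can be followed is an at least 34-fold lower number from compound 1 to compound 2 (1.53 log units; beyond the scatter), where the chloro of compound 1 is replaced by hydrogen.

The unmeasured compound 4 `COc1cc(-n2cnc3ccc(-c4ccc(Cl)cc4)cc32)cc(OC)c1OC` returns a chloro to compound 2, but at a different place: chloro in place of hydrogen on an aromatic carbon. Within the data shown here, no measured pair carries a chloro at this place, so the step from compound 1 to compound 2 is the only guide, and it shows a large loss when a chloro sits on this ring. From the compounds shown here alone, whether a chloro para to the large group behaves the same is unknown, so the expectation is wide and leans toward a weaker result.

Compound 4 is therefore expected to give about 1500 nM, within 250 nM to 10000 nM, which is an estimated step of a 5.2-fold higher number from compound 2 to compound 4 (0.71 log units; beyond the scatter).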

Compound 4, half-maximal inhibitory concentration: 1270 nM
The estimate for compound 4 lay 1.2-fold (0.07 log units) above the measured number; the measured number falls inside the stated range.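

In this assay, a chloro on this ring does not by itself remove the activity: placed para to a large group, on the six-membered aromatic ring of carbon only, it gives a 4.4-fold higher number from compound 2 to compound 4 (0.64 log units; beyond the scatter), a modest loss that leaves compound 4 clearly measurable. Moving the chloro, with phenyl carrying the same single substituent in both compounds, gives an at least 7.8-fold lower number from compound 1 to compound 4 (0.89 log units; beyond the scatter), so 4-chlorophenyl is tolerated far better than 2-chlorophenyl and the place of the chloro matters as well as its presence. Compound 1 gives only a limit, so the full size of that second step cannot be read: the limit of > 10000 nM in this assay, at which 2 of the 4 values shown sit.

The compounds shown leave open whether the modest loss at this place is particular to chloro, or whether another group on the same carbon, such as a methoxy, an amine or a carboxylic acid, would land nearer compound 2 or further from it. They also give no explanation of why the chloro costs activity at either place.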